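Replacing the cyanoethyl chain on the ring nitrogen

The source may report more compounds than this note shows. Statements on the series, on what has been measured and on what is new or still open speak of the compounds shown alone.

In a functional assay on the whole organism (stomach) for inhibition, with Rattus norvegicus as the target, at a dose of 100 mg/kg by the intraduodenal route (on this read-out lower numbers stand for less inhibition and higher numbers for more inhibition at the one dose given (going by the name of the read-out)), three compounds have been measured so far. Compound 1 `CC(Cn1ncccc1=O)C(=N)S` gives 40.3%, compound 3 `O=c1cccnn1CCC(=S)N1CCCC1` gives 29.7%, and compound 2 `N#CCCn1nc(-c2ccccc2)ccc1=O` gives 10.1%. Compound 2 stands lowest of the three: compound 3 lies closest to it, a gap that is beyond the usual scatter, and compound 1 lies furthest from it, also beyond the scatter.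

The step now followed leads from compound 2 to compound 4 `CC(CC(=N)S)n1nc(-c2ccccc2)ccc1=O`, which is not yet measured. The change is a group of 6 heavy atoms (4 carbon, 1 nitrogen, 1 sulfur; no ring) in place of a group of 4 heavy atoms (3 carbon, 1 nitrogen; no ring), on an aromatic nitrogen. The entering group shares the sulfur-containing chain end seen in compound 1 and, in a different form, in compound 3, both of which give higher numbers than compound 2.

Among the measured compounds shown here, no step between two measured compounds is available to guide the size of this change. A rise beyond the scatter in this assay is expected for the step of a number 19.9 percentage points higher from compound 2 to compound 4 (beyond the scatter), because compound 1 gives 40.3% and compound 3 gives 29.7%, each well above compound 2. Compound 4 is therefore estimated at 30%, with a range from 12% to 50%.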

Compound 4, a percentage reported as inhibition, in the whole organism at one dose (the size of the read-out at that dose, not a potency): 15.5%
Beside the measured number, compound 4's estimate is 14.5 percentage points above it; the measured number falls inside the stated range.
By their numbers in this assay, from the lowest: compounds 2 and 4 (each within the scatter of the next); then compound 3; then compound 1.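

Among the compounds shown here, on the shared core, exchanging the 2-cyanoethyl group on the aromatic nitrogen for the larger sulfur-bearing chain amounts to a number 5.4 percentage points higher from compound 2 to compound 4 (within the scatter), the first pair in this assay that isolates a change at this position. The entering chain carries a sulfur atom and hydrogen-bond donors that the 2-cyanoethyl group lacks, and it has a double bond outside the ring where the leaving group has a triple bond, yet at the one dose given the read-out does not separate the two compounds. No accompanying measurement is available to account for this result.

Compound 1 and compound 3 differ from compound 4 in more than one place, so the compounds shown cannot settle how much of their values belongs to the chain on the ring nitrogen and how much to the rest of the structure. As far as these compounds go, it also remains open whether an amine, a carboxylic acid or a longer chain at this nitrogen would move the number beyond the scatter on this core.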